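Adding Trifluoromethyl to a Weakly Cytotoxic Series

The compounds below may be only part of what the source reports. "The series", "measured", "known", "first", "only" and "open" are said of these compounds alone.

Of the compounds shown here, three from this series have been tested in a functional assay on MDA-MB-231 cells (Homo sapiens) for cytotoxicity, read by MTT assay, with a stated time of 72 h; a lower number here means a stronger inhibitor, a higher number a weaker inhibitor. Compound 1 `Cn1nc(-c2ccccc2)c2cc(C(=N)Nc3cccc(C(F)(F)F)c3)ncc21` gives 21400 nM in this assay, and compound 2 `COc1ccc(Cn2ncc3cc(C(=N)Nc4cccc(C(F)(F)F)c4)ncc32)cc1` gives 29800 nM. Both carry a trifluoromethyl on the aromatic ring attached to the shared core, but each also differs from the other elsewhere, so their two values show only that both are weak inhibitors.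

Compound 3 `Cn1ncc2cc(C(=N)Nc3ccccc3)ncc21` lacks that trifluoromethyl. In this assay compound 3 reaches only > 50000 nM, which is a limit of the measurement and not a number. Compound 3 therefore stands at the limit of > 50000 nM in this assay, at which 1 of the 3 values shown sits.

Compound 4 `Cn1ncc2cc(C(=N)Nc3cccc(C(F)(F)F)c3)ncc21` has not yet been measured in this assay. It differs from compound 3 by trifluoromethyl in place of hydrogen on an aromatic carbon. Among the compounds with values here, no measured step between two compounds exists for exactly this change, so its size can only be estimated. Since compound 1 and compound 2, which both carry the trifluoromethyl, give measurable numbers while compound 3 gives only a limit, a modest step toward stronger inhibition is expected, an at least 1.4-fold lower number from compound 3 to compound 4 (0.15 log units; that floor lies within the scatter), though with wide uncertainty. Compound 4 is expected to give about 35000 nM in this assay, within a range from 15000 nM to 80000 nM, with a real chance that it too reaches only a limit.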

Compound 4, half-maximal inhibitory concentration: > 50000 nM
Compound 4: a limit, no number (the forecaster's own chance of this, stated with the estimate: 40%); at least 1.4-fold (0.15 log units) between middle value and limit.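

In this assay compound 4 gives > 50000 nM, which is a limit of the assay and not a number, so trifluoromethyl in place of hydrogen on this aromatic carbon is not enough by itself to yield a measurable value. Compound 3 also ends at a limit, so the step between these two compounds cannot be read, and any gain from the trifluoromethyl stays hidden: the limit of > 50000 nM in this assay, at which 2 of the 4 values shown sit.

Within the data shown here, the new compound also gives the first comparisons with the two measurable compounds, an at least 1.6-fold higher number from compound 2 to compound 4 (0.22 log units; that floor lies within the scatter) where hydrogen replaces 4-methoxyphenyl, and an at least 2.3-fold higher number from compound 1 to compound 4 (0.36 log units; beyond the scatter) where hydrogen replaces phenyl, so only the phenyl step is clearly beyond the usual scatter of repeated measurements.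

What the trifluoromethyl contributes when the phenyl is also present remains open, as no pair shown differs by that group alone with a number on both sides. Going by these compounds, it is also open whether another group in the place of the trifluoromethyl, such as an amine or a carboxylic acid, would give a measurable value on the core of compound 4.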